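The source may report more compounds than this note shows. Statements on the series, on what has been measured and on what is new or still open speak of the compounds shown alone.

Working notes on the series.

Of the compounds shown here, three share a core and have been measured in a functional assay on U-87MG ATCC cells for antiproliferative activity against U-87 MG (Homo sapiens), read by MTT assay, with a stated time of 48 h, tested at 10 uM; on this read-out lower numbers stand for a stronger effect and higher numbers for a weaker effect at the one concentration tested. Compound 1, `Cc1nc(-c2ccccc2)sc1C(=O)CSc1nc(-c2ccc(Cl)c(Cl)c2)c(C#N)c(=O)[nH]1`, gives 92.5% in this assay. Compound 2, `Cc1nc(-c2ccccc2)sc1C(=O)CSc1nc(-c2ccccc2)c(C#N)c(=O)[nH]1`, gives 87.5% in this assay. Compound 3, `COc1ccc(-c2nc(C)c(C(=O)CSc3nc(-c4ccc(Cl)c(Cl)c4)c(C#N)c(=O)[nH]3)s2)cc1`, gives 88.6% in this assay. The three numbers sit close together, and no order among them can be read from this assay.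

One change, (phenyl in place of 3,4-dichlorophenyl on an aromatic carbon), gives the step of a number 5 percentage points lower from compound 1 to compound 2 (within the scatter). A second change, (methoxy in place of hydrogen on an aromatic carbon), gives the step of a number 3.9 percentage points lower from compound 1 to compound 3 (within the scatter). Compound 2 and compound 3 were not measured as a pair with a counted step; their two values in this assay lie within the usual scatter of each other.

Compound 4, `COc1ccc(-c2nc(C)c(C(=O)CSc3nc(-c4ccccc4)c(C#N)c(=O)[nH]3)s2)cc1`, has not yet been measured in this assay. It differs from compound 3 by phenyl in place of 3,4-dichlorophenyl on an aromatic carbon. This is the same change as that from compound 1 to compound 2: the group that leaves, the group that enters and the place where it happens read identically. The cores of compound 3 and compound 4 differ from those of compound 1 and compound 2 by methoxy in place of hydrogen on an aromatic carbon.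

For compound 4 the step from compound 3 is expected to be about a number 4.6 percentage points lower from compound 3 to compound 4 (within the scatter), set beside the measured step of a number 5 percentage points lower from compound 1 to compound 2 (within the scatter), because that step was within the scatter. Compound 4 is therefore estimated at 84% in this assay, with an expected range from 74% to 95%.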

Compound 4, a percentage reported as activity, at one concentration (the size of the read-out at that concentration, not a potency): 90.9%
For compound 4 the middle estimate is 6.9 percentage points below the measured one, and the stated range covers the measured number.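

In this assay, phenyl in place of 3,4-dichlorophenyl on the core carrying the methoxy group gives a number 2.3 percentage points higher from compound 3 to compound 4 (within the scatter), and this step does not differ from the earlier one: the same change on two cores in this assay, a number 5 percentage points lower (within the scatter) from compound 1 to compound 2 and a number 2.3 percentage points higher (within the scatter) from compound 3 to compound 4, 7.3 percentage points apart, within the scatter of two such steps. Methoxy in place of hydrogen on the core carrying phenyl gives a number 3.4 percentage points higher from compound 2 to compound 4 (within the scatter), and this step does not differ from its earlier counterpart either: the same change on two cores in this assay, a number 3.9 percentage points lower (within the scatter) from compound 1 to compound 3 and a number 3.4 percentage points higher (within the scatter) from compound 2 to compound 4, 7.3 percentage points apart, within the scatter of two such steps. So neither change moves the read-out beyond the scatter on either core, but since no step is large enough to read, this does not show that an effect carries from one core to the other, and the opposite directions of the paired steps cannot be taken as a reversal.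

The compounds shown leave open whether either change would carry over on a core where its step stands clear of the scatter. They also leave open how the read-out would respond to quite different groups, such as an amine or a carboxylic acid in place of the methoxy group, or a longer chain in place of the methyl group on the shared core.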